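The compounds below may be only part of what the source reports. "The series", "measured", "known", "first", "only" and "open" are said of these compounds alone.

Measured compounds in a functional assay on PC-3 cells (Homo sapiens) for cytotoxicity, read by sulforhodamine B assay, with a stated time of 72 h; a lower number here means a stronger inhibitor, a higher number a weaker inhibitor:
- compound 1 `CCCCC/C=C\C[C@@]1(O)C=C(Cl)C(=O)/C1=C/C=C/CCCC(=O)OC` gives 1900 nM
- compound 2 `CCCCC/C=C\C[C@@]1(O)C=C(I)C(=O)/C1=C/C=C/CCCC(=O)OC` gives 3900 nM
- compound 3 `CCCCC/C=C\C[C@@]1(O)C=C(Br)C(=O)/C1=C/C=C/CCCC(=O)OC` gives 5600 nM

Compound 2 stands second highest of the three numbers. Its nearest neighbour is compound 3, with a 1.4-fold higher number from compound 2 to compound 3 (0.16 log units; within the scatter), a gap within the scatter, so no order between compound 2 and compound 3 can be read. Its furthest neighbour is compound 1, with a 2.1-fold higher number from compound 1 to compound 2 (0.31 log units; beyond the scatter), beyond the scatter; the related step of a 2.9-fold higher number from compound 1 to compound 3 (0.47 log units; beyond the scatter) points the same way. All three measured steps are exchanges of the halogen on the double-bonded ring carbon and are modest at most.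

Compound 4 `CCCCC/C=C\C[C@@]1(O)C=C(I)C(=O)/C1=C\C=C\CCCC(=O)OC` differs from compound 2 as follows: the two compounds have the same atoms and bonds and differ only in configuration as drawn: 1 of 4 stereo elements differ; a double bond is drawn E in compound 2 and Z in compound 4. For the measured compounds named here, none of the measured steps changes the configuration of a double bond, so none bears on this step; the halogen exchanges give no direction for it. Going by the values given here, with no comparable step available, the expectation for compound 4 is a number close to that of compound 2 with a wide range, an expected step of a 1.4-fold higher number from compound 2 to compound 4 (0.15 log units; within the scatter). The estimate for compound 4 in this assay is 5500 nM, expected to fall between 1500 nM and 20000 nM.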

Compound 4, half-maximal inhibitory concentration: 6700 nM
Compound 4: the middle estimate sits 1.2-fold (0.09 log units) below what was measured, within the range that was stated.
By their numbers in this assay, from the lowest: compound 1; then compounds 2, 3 and 4 (each within the scatter of the next).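

In this assay, for the compounds shown here, the configuration of a double bond comes into play for the first time, and the result is a 1.7-fold higher number from compound 2 to compound 4 (0.24 log units; within the scatter), so no order between these two compounds can be read. The earlier steps shown here exchanged only the halogen on the double-bonded ring carbon, whereas this one shows that, with iodo in that place, drawing the double bond Z rather than E gives no change that can be told from the scatter. The comparison is a clean one, with no exchanged group to weigh against the configuration: the fact that compounds 2 and 4 differ only in the configuration as drawn

As far as these compounds go, it remains open whether the same holds with chloro or bromo on that ring carbon. Also open, from the compounds shown here alone, is how a nitrile there, or a carboxylic acid in place of the methyl ester, would read in this assay.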